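The source may hold more compounds than are shown below. What is called first, only, known or untested is meant among the compounds shown, and "the series" means these compounds.

Working notes on the series. Compound 1 `CCCCCCCC/C=C\CCCCCCC(=O)c1ccccc1` stands at a limit in an assay on isolated protein for inhibition of Fatty-acid amide hydrolase 1 (Homo sapiens); on this read-out higher numbers stand for weaker inhibition and lower numbers for stronger inhibition: compound 1 gives > 100000 nM, which is a limit of the assay and not a number. Compound 2 `CCCCCCCC/C=C\CCCCCCCC(OC)OC` also sits at a limit, giving > 300000 nM in this assay. Compound 3 `CCCCCCCC/C=C\CCCCCCC(=O)c1nc2cc(C)ccc2o1` likewise gives > 100000 nM in this assay, again a limit. Among the measured compounds shown here, the only step measured in one place, a step that the two limits leave unreadable from compound 1 to compound 2, is unreadable because the limit of > 100000 nM in this assay, at which 2 of the 3 values shown sit, and the limit of > 300000 nM in this assay, at which 1 of the 3 values shown sits, leave no number to compare. Compound 4 `CCCCCCCC/C=C\CCCCCCC(=O)c1nc2ncccc2o1` differs from compound 1 by a group of 9 heavy atoms (6 carbon, 2 nitrogen, 1 oxygen; one five-membered aromatic ring with 2 hetero atoms, one six-membered aromatic ring with 1 hetero atom) in place of a group of 6 heavy atoms (6 carbon; one six-membered aromatic ring of carbon only), on a carbonyl carbon. For the measured compounds named here, no measured step touches the carbonyl carbon, so none bears directly on this change; the step from compound 1 to compound 2 concerns another place and is unreadable in any case. Going by the values given here, compound 3 carries a group on the same carbonyl carbon and sits at a limit, which is the only near comparison available. The step of a number no higher from compound 1 to compound 4 (the limit leaves the size open) is therefore expected to stay within the scatter or to leave compound 4 at a limit. Compound 4 is estimated at 100000 nM, with a range from 1000 nM to 300000 nM.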

Compound 4, inhibition constant: 2.3 nM
Estimate against measurement, compound 4: 43000-fold (4.64 log units) above; the whole stated range lies above it.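

Among the compounds shown here, on a carbonyl carbon, the group with one five-membered aromatic ring with 2 hetero atoms and one six-membered aromatic ring with 1 hetero atom, in place of phenyl, gives an at least 43000-fold lower number from compound 1 to compound 4 (4.63 log units; beyond the scatter) in this assay, the first readable step. As far as these compounds go, the full size of this step stays open because compound 1 stands at a limit of the assay: the limit of > 100000 nM in this assay, at which 2 of the 4 values shown sit. Compound 3, with a different group on the same carbonyl carbon, gives > 100000 nM, which is also a limit of the assay, so a group on this carbon does not by itself bring a compound off the limit.

The compounds shown do not tell which atoms of the entering group carry the step. From the compounds shown here alone, it also remains open whether the value holds with a shorter chain, a fully saturated chain, or a carboxylic acid or amine on the six-membered ring.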